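Shortening the Ester Side Chain and Adenosine Receptor Binding

The compounds below may be only part of what the source reports. "The series", "measured", "known", "first", "only" and "open" are said of these compounds alone.

Four related compounds are compared here. Compound 1 `COC(=O)C1=C(C)N(C)C(=O)NC1c1ccsc1` and compound 2 `CCOC(=O)C1=C(C)N(C)C(=O)NC1c1ccsc1` share one core and differ in a single place. In an assay on membranes from HEK293 cells for displacement of a labelled ligand from adenosine receptor A2b (Homo sapiens), read by scintillation counting, with a stated time of 30 min, tested at 1 uM (a higher number here means more inhibition at the concentration tested (going by the name of the read-out), a lower number less inhibition), compound 2 gives 53%, while compound 1 gives 26%. The change from compound 2 to compound 1 is hydrogen in place of methyl on a saturated chain carbon bound to an oxygen next to a carbonyl group, and it produced a number 27 percentage points lower from compound 2 to compound 1 (beyond the scatter).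

Compound 3 `CCC(CC)OC(=O)C1=C(C)NC(=O)NC1c1cccs1` is built on a different core; how its core differs from that of compound 2 is not broken down here. In this assay compound 3 gives 6%, the lowest of the three measured numbers.

Compound 4 `CCC(C)OC(=O)C1=C(C)NC(=O)NC1c1cccs1` has not yet been measured. It is obtained from compound 3 by hydrogen in place of methyl on a saturated chain carbon, two bonds along the chain from an oxygen next to a carbonyl group. Within the data shown here, this is the same kind of change as the one from compound 2 to compound 1, not the same one: there the saturated chain carbon was bound to an oxygen next to a carbonyl group, whereas here it lies two bonds along the chain from an oxygen next to a carbonyl group. The earlier step lowered inhibition, yet compound 3 already sits near the bottom of the range. The step from compound 3 to compound 4 is therefore expected to be a number 2 percentage points lower from compound 3 to compound 4 (within the scatter), small because compound 3 already gives 6%. Compound 4 is expected to give 4% in this assay, most likely between -8% and 22%.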

Compound 4, a percentage reported as inhibition, at one concentration (the size of the read-out at that concentration, not a potency): 7%
The estimate for compound 4 lay 3 percentage points below the measured number; the range from low to high includes it.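

In this assay, putting hydrogen in place of methyl on the ester chain gives a number 1 percentage points higher from compound 3 to compound 4 (within the scatter), so the drop seen on the core of compound 2 does not reappear on the core of compound 3: the same change on two cores in this assay, a number 27 percentage points lower (beyond the scatter) from compound 2 to compound 1 and a number 1 percentage points higher (within the scatter) from compound 3 to compound 4, 28 percentage points apart, beyond the scatter of two such steps.

This shows that, for these two pairs, the result of trimming the chain on one core cannot be assumed for the other. It does not show why, since the two pairs differ in their cores and also in where on the chain the methyl is lost, and compound 3, at 6%, already starts with little room for any further fall to be seen.

The compounds shown leave open how the same change would behave at each chain place on a single core, which would separate the place from the core. They also leave open what a carboxylic acid in place of the ester, or an amine on the ester chain, would do to inhibition.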